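The source may report more compounds than this note shows. Statements on the series, on what has been measured and on what is new or still open speak of the compounds shown alone.

Compound 1, `COCc1cccc(-c2ccc3ccc(C)nc3c2)c1`: 5800 nM
Compound 2, `Cc1ccc2ccc(-c3cc(C#N)cc(C#N)c3)cc2n1`: 2 nM

Both compounds were tested in a functional assay on CHO cells for inhibition of metabotropic glutamate receptor 5 (Rattus norvegicus), read by FLIPR and calcium flux; on this read-out higher numbers stand for weaker inhibition and lower numbers for stronger inhibition. Of the two numbers, compound 2 has the lower one, and the gap between compound 2 and compound 1 lies far beyond the usual scatter of repeated measurements. Among the measured compounds shown here, no single-change step between measured compounds is available here, so the pair shows only the two numbers as they stand.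

Compound 3, `COCc1cc(C#N)cc(-c2ccc3ccc(C)nc3c2)c1`, has not been measured. It differs from compound 2 in one place: methoxymethyl in place of cyano on an aromatic carbon. Compound 1 also carries a methoxymethyl group and no cyano group, and in this assay compound 1 gives 5800 nM. Compound 3 keeps one cyano group and takes a methoxymethyl group where the other stood, so its structure sits between the two measured compounds. The expected step from compound 2 to compound 3 is therefore a weakening, a 15-fold higher number from compound 2 to compound 3 (1.18 log units; beyond the scatter), beyond the scatter yet well short of the whole distance to compound 1. Compound 3 is estimated in this assay at 30 nM, with a range from 8 nM to 150 nM.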

Compound 3, half-maximal inhibitory concentration: 2 nM
For compound 3 the middle estimate is 15-fold (1.18 log units) above the measured one, and the stated range ends above it.
By their numbers in this assay, from the lowest: compounds 2 and 3 (each within the scatter of the next); then compound 1.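

The position that held the second cyano group in compound 2 turns out to accept methoxymethyl, a group with more heavy atoms, without any loss in this assay: the swap gives no change at the digits printed from compound 2 to compound 3 (within the scatter). The weak number of compound 1 therefore cannot be read as a penalty for carrying methoxymethyl as such, since compound 3 carries the same group, and the change that matters is a different one: cyano in place of hydrogen on an aromatic carbon gives a 2900-fold lower number from compound 1 to compound 3 (3.46 log units; beyond the scatter), a very large step for so small an addition. Nothing measured here explains why the cyano group counts for so much at one place and can be replaced at the other.

The compounds shown leave open how much variety the methoxymethyl position accepts, for instance a longer chain such as ethoxymethyl, an amine or a carboxylic acid. They also leave open whether the remaining cyano group could give way to another small group, such as chlorine or fluorine, and still keep the number this low.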